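Shifting the nitro group on the pendant aryl ring

The compounds below may be only part of what the source reports. "The series", "measured", "known", "first", "only" and "open" are said of these compounds alone.

The series is measured in a functional assay on the whole organism (plasma, strain Wistar) with Rattus norvegicus as the target, with a stated time of 15 days, at a dose of 30 mg/kg by the oral route; on this read-out lower numbers stand for a weaker effect and higher numbers for a stronger effect at the one dose given. Compound 1 `Cc1ccc(-c2nnc(SCCOc3ccc(/C=C4\SC(=O)NC4=O)cc3)[nH]2)cc1` gives 22.6% in this assay, and compound 2 `O=C1NC(=O)/C(=C/c2ccc(OCCSc3nnc(-c4ccc([N+](=O)[O-])cc4)[nH]3)cc2)S1` gives 16%. Among the measured compounds shown here, the single measured step, a number 6.6 percentage points lower from compound 1 to compound 2 (within the scatter), is the only comparison available. On the two numbers shown, compound 2 stands lowest, yet its nearest neighbour is compound 1 and the gap between them lies within the scatter, so the two cannot be ordered.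

Compound 3 `O=C1NC(=O)/C(=C/c2ccc(OCCSc3nnc(-c4ccccc4[N+](=O)[O-])[nH]3)cc2)S1` differs from compound 2 only as 2-nitrophenyl in place of 4-nitrophenyl on an aromatic carbon, the nitro group changing its position on the pendant aryl ring while everything else in the shared core is kept.

The step from compound 1 to compound 2 bears on this change only in so far as it concerns the same place on the shared core; it was a small step, inside the scatter, and gives no sign that this position is sensitive. The estimate for compound 3 is therefore no change at the digits printed from compound 2 to compound 3 (within the scatter), a step not expected to exceed the scatter. Compound 3 is expected to give 16% in this assay, within 5% to 28%.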

Compound 3, a percentage reported as activity, at one dose (the size of the read-out at that dose, not a potency): 20.1%
Compound 3: middle estimate off by 4.1 percentage points, on the low side; measured number inside the range.
By their numbers in this assay, from the lowest: compounds 2, 3 and 1 (each within the scatter of the next).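

Among the compounds shown here, the change of 2-nitrophenyl in place of 4-nitrophenyl on this aromatic carbon gives a number 4.1 percentage points higher from compound 2 to compound 3 (within the scatter) in this assay and is the first reading of what moving the nitro group around the pendant ring does, and it does not separate the two arrangements. For the compounds shown here, the change of 2-nitrophenyl in place of 4-methylphenyl at the same place gives a number 2.5 percentage points lower from compound 1 to compound 3 (within the scatter) and closes the set of comparisons, so that 4-methylphenyl, 4-nitrophenyl and 2-nitrophenyl all lie within the scatter of one another and no step among the three shows this position to be sensitive to the change of aryl group. Nothing available explains these numbers or bears on a cause for them.

Still open, on these data alone, is whether this place would hold its read-out with something other than a substituted phenyl ring, such as an amine, a carboxylic acid or a longer chain on the pendant ring. As far as these compounds go, the read-out is the size of an effect at the one dose given, so how these compounds compare at any other dose also remains open.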